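The compounds below may be only part of what the source reports. "The series", "measured", "known", "first", "only" and "open" are said of these compounds alone.

Measured compounds:
- compound 1 `NNC(=O)CCc1ccncc1-c1ccc2ccccc2c1`: 7.7 nM
- compound 2 `O=C(COc1ccncc1-c1ccc2ccccc2c1)N1CCOCC1`: "not determined" (no result reported)
- compound 3 `O=C(O)COc1ccncc1-c1ccc2ccccc2c1`: "not determined" (no result reported)

In an assay on a protein complex for inhibition of CDK8/Cyclin C (Homo sapiens), with a stated time of 1 h (on this read-out higher numbers stand for weaker inhibition and lower numbers for stronger inhibition), compound 1 gives 7.7 nM. For compound 2 the result in this assay is "not determined" (no result reported), and for compound 3 the result in this assay is likewise "not determined" (no result reported). Compound 3 therefore stands nowhere on the numbers: it shares the core of compound 1 but carries a carboxymethoxy group where compound 1 carries its chain, and no value exists for it, nor for compound 2. For the measured compounds named here, the only number is that of compound 1.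

The step from compound 3 to compound 4 `NC(=O)/C=C/c1ccncc1-c1ccc2ccccc2c1` is the change (2-carbamoylethenyl in place of carboxymethoxy on an aromatic carbon). With compound 3 lacking a number, no size or direction of step in this assay can be set from the data; the expectation for compound 4 rests on compound 1 alone, whose chain on the same aromatic carbon, ortho to a large group and opposite the ring nitrogen, ends in an amide-like carbonyl much as the 2-carbamoylethenyl group does. Compound 4 is therefore expected to land in this assay near 15 nM, within the range 3 nM to 80 nM, the estimate resting on compound 1 and its 7.7 nM.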

Compound 4, half-maximal inhibitory concentration: 10.5 nM
Beside the measured number, compound 4's estimate is 1.4-fold (0.15 log units) above it; low and high end bracket the measured number.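

In this assay, 2-carbamoylethenyl in place of 2-(aminocarbamoyl)ethyl gives a 1.4-fold higher number from compound 1 to compound 4 (0.13 log units; within the scatter), so on this aromatic carbon, ortho to a large group and opposite the ring nitrogen, the two groups cannot be told apart on this read-out. The position now has a second number, and the value for compound 1 no longer stands alone: two different chains on this carbon give values within the scatter of each other. Compound 2 and compound 3 have no number, so steps involving them cannot be read, and nothing on hand explains the closeness of the two values.

The compounds shown leave open how far this tolerance extends: whether an amine, a nitrile or a longer chain ending in a primary amide on the same carbon would hold the number in this assay. They also leave open whether the amide end of the chain matters at all, which a comparison with a plain ethyl group on this carbon could address.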